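The compounds below may be only part of what the source reports. "The series", "measured", "known", "first", "only" and "open" are said of these compounds alone.

Measured in a functional assay on CCRF-CEM cells (Homo sapiens) for antiproliferative activity, read by trypan blue exclusion, with a stated time of 72 h; on this read-out higher numbers stand for weaker inhibition and lower numbers for stronger inhibition:
Compound 1 `C[C@@H](Br)C(=O)Nc1cccc(C(=O)NC(N)=O)c1`: 1470 nM
Compound 2 `Cc1ccc(NC(=O)C(C)Br)cc1C(=O)NC(N)=O`: > 20000 nM (a limit of the assay)
Compound 3 `Cc1ccc(NC(=O)CBr)cc1C(=O)NC(N)=O`: 4760 nM

Compound 3, at 4760 nM, has the higher of the two exact numbers, and compound 1 gives 1470 nM, a gap beyond the scatter. Compound 2 reads > 20000 nM, which is only a limit of the assay.

The next compound is compound 4 `NC(=O)NC(=O)c1cc(NC(=O)CBr)ccc1Cl`. It differs from compound 3 as follows: chloro in place of methyl on an aromatic carbon. Thus compound 4 carries chloro where compound 3 carries methyl, ortho to a carbamoylcarbamoyl group and para to a ((bromomethyl)carbonyl)amino group.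

Going by the values given here, only one measured step links two compounds that differ in one place: an at least 4.2-fold lower number from compound 2 to compound 3 (0.62 log units; beyond the scatter). That step is beyond the scatter, but it concerns the saturated chain carbon bound to bromine, not the aromatic carbon that changes here. It shows that a single-place change can move the number in this assay, yet it gives neither size nor direction for this replacement. Among the compounds with values here, with no measured step on this aromatic carbon, the expectation stays anchored on compound 3 at 4760 nM, and no shift beyond the scatter is expected. The estimated step is a 1.4-fold lower number from compound 3 to compound 4 (0.13 log units; within the scatter). For compound 4 the expected value is 3500 nM, with an estimated range from 1200 nM to 11000 nM.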

Compound 4, half-maximal inhibitory concentration: 540 nM
For compound 4 the middle estimate is 6.5-fold (0.81 log units) above the measured one; the whole stated range lies above it.
By their numbers in this assay, from the lowest: compound 4; then compound 1; then compound 3. At a limit, above all of these: compound 2.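

In this assay, the aromatic carbon ortho to a carbamoylcarbamoyl group and para to a ((bromomethyl)carbonyl)amino group proves to be a place where a single replacement matters: chloro in place of methyl gives an 8.8-fold lower number from compound 3 to compound 4 (0.95 log units; beyond the scatter), a step beyond the scatter towards stronger inhibition. Going by these compounds alone, the only earlier single-place step, an at least 4.2-fold lower number from compound 2 to compound 3 (0.62 log units; beyond the scatter), lay on the saturated chain carbon bound to a bromine atom and a carbonyl carbon, so this is the first measured size and direction for a change on the aromatic carbon. Nothing measured here accounts for the size of this step, and no property of methyl or chloro is given that bears on it.

Going by these compounds, with only methyl and chloro compared on this carbon, it remains open whether fluoro, bromo, methoxy or a nitrile there would give a lower or a higher number than chloro. On these data alone, it also remains open whether chloro in place of methyl would produce a comparable step when the chain carbon bound to bromine carries a methyl, as it does in compound 2.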